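Benzylamine variation on a bis(trifluoromethyl)sulfonamide series

The compounds below may be only part of what the source reports. "The series", "measured", "known", "first", "only" and "open" are said of these compounds alone.

Measured so far:
compound 1 `CC(C)(C)c1ccc(CNCCCNS(=O)(=O)c2cc(C(F)(F)F)cc(C(F)(F)F)c2)cc1` — 2900 nM
compound 2 `O=S(=O)(NCCCNCC1COc2ccccc2O1)c1cc(C(F)(F)F)cc(C(F)(F)F)c1` — 1500 nM
compound 3 `O=S(=O)(NCCCNCc1ccc(C(F)(F)F)cc1)c1cc(C(F)(F)F)cc(C(F)(F)F)c1` — 2800 nM

All three compounds share the sulfonamide-propylamine core and differ only in the group on the saturated chain carbon bound to the amine nitrogen. In a functional assay on A2780 cells (Homo sapiens) for inhibition, read by MTT assay, with a stated time of 72 h (a higher number here means a weaker inhibitor of growth, a lower number a stronger inhibitor of growth), compound 3 gives 2800 nM, the second highest of the three numbers; its nearest neighbour is compound 1 at a 1.0-fold lower number from compound 1 to compound 3 (0.02 log units; within the scatter), its furthest compound 2 at a 1.9-fold higher number from compound 2 to compound 3 (0.27 log units; within the scatter), both within the scatter.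

Compound 4 `O=S(=O)(NCCCNCc1cccc(Cl)c1)c1cc(C(F)(F)F)cc(C(F)(F)F)c1` is not yet measured. Against compound 3 the change is 3-chlorophenyl in place of 4-(trifluoromethyl)phenyl on a saturated chain carbon bound to an amine nitrogen. Going by the values given here, the steps that bear on it are the exchanges at the same place: a 1.9-fold lower number from compound 1 to compound 2 (0.29 log units; within the scatter), a 1.0-fold lower number from compound 1 to compound 3 (0.02 log units; within the scatter) and a 1.9-fold higher number from compound 2 to compound 3 (0.27 log units; within the scatter). Among the compounds with values here, none of them exceeds the scatter, so every variation at this position so far has left this assay essentially unchanged. A step of similar size, in no preferred direction, is therefore expected for compound 4: a 1.0-fold lower number from compound 3 to compound 4 (0.02 log units; within the scatter).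

Compound 4 is estimated at 2700 nM, in the range 1200 nM to 6000 nM.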

Compound 4, concentration for 50% growth inhibition: 2200 nM
Compound 4: middle estimate off by 1.2-fold (0.09 log units), on the high side; the range from low to high includes it.
By their numbers in this assay, from the lowest: compounds 2, 4, 3 and 1 (each within the scatter of the next).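

In this assay, the 3-chlorophenyl group of compound 4 does not separate from any of the three earlier groups (a 1.3-fold lower number from compound 3 to compound 4 (0.10 log units; within the scatter)) (a 1.5-fold higher number from compound 2 to compound 4 (0.17 log units; within the scatter)) (a 1.3-fold lower number from compound 1 to compound 4 (0.12 log units; within the scatter)). The exchange of 4-(trifluoromethyl)phenyl, with 10 heavy atoms, for 3-chlorophenyl, with 7, adds a chlorine-bearing ring and a smaller group to the set, and all four groups at this place on a saturated chain carbon bound to an amine nitrogen still read alike within the scatter. No measurement is available that bears on why these groups read alike.

Going by these compounds, whether a carboxylic acid or a pyridyl group at this place would give a step beyond the scatter remains open. The same question stands for a longer chain in the shared core.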